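The source may report more compounds than this note shows. Statements on the series, on what has been measured and on what is new or still open speak of the compounds shown alone.

Measured so far in a functional assay on KBVIN cells (Homo sapiens) for antiproliferative activity, read by sulforhodamine B assay, with a stated time of 3 days; a higher number here means that more compound is needed for the effect, a lower number that less compound is needed:

- compound 1 `CCC1=C(O)c2c(oc(-c3ccc(CC)cc3)cc2=O)C(CC)(CC)C1=O` gives 0.07 uM
- compound 2 `CCCOc1ccc(-c2cc(=O)c3c(o2)C(CC)(CC)C(=O)C(CC)=C3O)cc1` gives 29.2 uM

Of the two, compound 2 has the higher number (29.2 uM), so it needs more compound for the effect than compound 1 does. Compound 3 `CCC1=C(O)c2c(oc(-c3ccc(F)cc3)cc2=O)C(CC)(CC)C1=O` departs from compound 2 by a single change, fluoro in place of propoxy on an aromatic carbon, para to a large group (fluoro in place of propoxy on an aromatic carbon). Going by the values given here, only one measured step bears on this change. It is a 420-fold higher number from compound 1 to compound 2 (2.62 log units; beyond the scatter), a step that exchanges ethyl for propoxy. That large step suggests that losing the propoxy should give a clearly lower number in this assay. Among the compounds with values here, no measured compound carries fluoro, however, and fluoro is not ethyl, so a full return to the value of compound 1 (0.07 uM) cannot be assumed. A large drop that stops short of that value is the more cautious expectation, and the range is kept wide. For compound 3 the estimated value is 1 uM, with an expected range from 0.1 uM to 12 uM. This estimate amounts to an expected 29-fold lower number from compound 2 to compound 3 (1.47 log units; beyond the scatter).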

Compound 3, concentration for half-maximal effect: 1.85 uM
For compound 3 the middle estimate is 1.9-fold (0.27 log units) below the measured one; measured number inside the range.
By their numbers in this assay, from the lowest: compound 1; then compound 3; then compound 2.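

In this assay the exchange of propoxy for fluoro on this aromatic carbon, para to a large group, gives a 16-fold lower number from compound 2 to compound 3 (1.20 log units; beyond the scatter) and so shows that the high number of compound 2 is not shared by every other group at this place. Fluoro does not match ethyl, however: the comparison of these two groups gives a 26-fold higher number from compound 1 to compound 3 (1.42 log units; beyond the scatter) and shows that the position also separates two groups other than propoxy, so that ethyl, fluoro and propoxy now stand in that order from the lowest number, with every step beyond the scatter. Nothing measured about these groups accompanies the numbers, so the order remains a description without an explanation.

Going by these compounds, whether the high number of compound 2 goes with the oxygen atom of propoxy or with the length of its chain stays open, and a methoxy group and a plain propyl chain at this place would begin to separate the two. On these data alone, how a chloro group, an amine or a carboxylic acid would stand at this position, relative to ethyl and fluoro, is also open.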